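The compounds below may be only part of what the source reports. "The series", "measured", "known", "first", "only" and "open" are said of these compounds alone.

Measured compounds:
compound 1 `Fc1ccc(-n2c(S)nnc2Sc2nnc(-c3ccccc3)n2-c2ccccc2)cc1`, 32800 nM
compound 2 `Sc1nnc(CSc2nnc(-c3ccccc3)n2-c2ccccc2)n1-c1ccc(Cl)cc1`, 36600 nM

In a functional assay on HT-29 cells (Homo sapiens) for inhibition, read by MTT assay, with a stated time of 48 h (a lower number here means a stronger inhibitor, a higher number a weaker inhibitor), compound 1 gives the lower of the two numbers, but compound 2 sits within the scatter of it, so the two are not told apart. Compound 3 `CCOc1ccc(-n2c(S)nnc2Sc2nnc(-c3ccccc3)n2-c2ccccc2)cc1` differs from compound 1 by ethoxy in place of fluoro on an aromatic carbon. For the measured compounds named here, no step between measured compounds of this kind is known here, so the step from compound 1 to compound 3 is expected to be a 1.1-fold lower number from compound 1 to compound 3 (0.04 log units; within the scatter), none beyond the scatter, in no set direction. Compound 3 is therefore estimated at 30000 nM, with a range from 12000 nM to 80000 nM.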

Compound 3, half-maximal inhibitory concentration: 46800 nM
For compound 3 the middle estimate is 1.6-fold (0.19 log units) below the measured one; the measured number falls inside the stated range.
By their numbers in this assay, from the lowest: compounds 1, 2 and 3 (each within the scatter of the next).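

In this assay the change from 4-fluorophenyl to 4-ethoxyphenyl gives a 1.4-fold higher number from compound 1 to compound 3 (0.15 log units; within the scatter) and so shows that this place, para to a large group, accepts ethoxy in place of fluoro with no shift that can be told from the scatter. For the compounds shown here, the result is the first reading of a change at this position on the shared core. No measurement available here offers an explanation for this result. The compounds shown leave open whether an amine, a carboxylic acid or a chain longer than ethoxy at this place would move the number beyond the scatter.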